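Swapping pyrrolidin-1-yl for pyridin-2-yl in compound 3

The source may hold more compounds than are shown below. What is called first, only, known or untested is meant among the compounds shown, and "the series" means these compounds.

Of the compounds shown here, three have been measured in a physicochemical assay for lipophilicity; on this read-out higher numbers stand for higher lipophilicity and lower numbers for lower lipophilicity. Compound 1 `CN1CCC(C(=O)N(CC(=O)Nc2cc(F)cc(F)c2)C2CCCCC2)CC1` gives 1.8, compound 2 `O=C(CN(C(=O)c1ccc(-n2ccnc2)cc1)C1CCCCC1)Nc1cc(F)cc(F)c1` gives 2.7, and compound 3 `O=C(CN(C(=O)c1ccc(N2CCCC2)cc1)C1CCCCC1)Nc1cc(F)cc(F)c1` gives 4.5, the highest of the three numbers.

Compound 4 `O=C(CN(C(=O)c1ccc(-c2ccccn2)cc1)C1CCCCC1)Nc1cc(F)cc(F)c1` has not yet been measured. Its difference from compound 3 is pyridin-2-yl in place of pyrrolidin-1-yl on an aromatic carbon. In words, pyridin-2-yl stands in place of pyrrolidin-1-yl on an aromatic carbon.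

Among the compounds with values here, one measured step bears on this change. The same place was altered in a number 1.80 log units higher from compound 2 to compound 3 (beyond the scatter), a large step beyond the scatter, with pyrrolidin-1-yl in place of 1H-imidazol-1-yl. The entering pyridin-2-yl is also an aromatic ring, and compound 2, which carries 1H-imidazol-1-yl, stands at 2.7. A fall in this assay is therefore expected, though only part of the size of that measured step. The expected step is a number 0.60 log units lower from compound 3 to compound 4 (beyond the scatter). For compound 4 the estimated value is 3.9, with an expected range from 3.4 to 4.4.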

Compound 4, distribution coefficient: 3.7
Beside the measured number, compound 4's estimate is 0.20 log units above it, within the range that was stated.
By their numbers in this assay, from the lowest: compound 1; then compound 2; then compound 4; then compound 3.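

In this assay, the aromatic carbon para to a large group now has a third group to compare, and pyridin-2-yl gives a number 0.80 log units lower from compound 3 to compound 4 (beyond the scatter) while also giving a number 1.00 log units higher from compound 2 to compound 4 (beyond the scatter) in the same sentence of comparison. Within the data shown here, the single large step seen earlier therefore divides into two modest ones, with compound 4 separated from both compound 2 and compound 3 beyond the scatter. Since compound 2 and compound 4 both carry an aromatic ring at this place yet do not read alike, having an aromatic ring there does not alone set the number.

Still open, on these data alone, is where a plain phenyl ring or a morpholin-4-yl ring would fall at this position. It is also open whether pyridin-3-yl or pyridin-4-yl would match pyridin-2-yl, and no measurement shown accounts for these steps.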